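The source may report more compounds than this note shows. Statements on the series, on what has been measured and on what is new or still open speak of the compounds shown alone.

Measured compounds:
compound 1 `CC(C)S(=O)(=O)c1ccc(S(=O)(=O)N2CCC[C@@H](C(=O)N3CCC(F)(F)CC3)C2)cc1` gives 50 nM in a functional assay on BXPC-3 cells (Homo sapiens) for inhibition, read by MTT assay, with a stated time of 7 days; a lower number here means a stronger inhibitor, a higher number a weaker inhibitor
compound 2 `O=C([C@@H]1CCCN(S(=O)(=O)c2ccc(S(=O)(=O)C3CC3)cc2)C1)N1CCC(F)(F)CC1` gives 129 nM in this assay
compound 3 `CN(C)S(=O)(=O)c1ccc(S(=O)(=O)N2CCC[C@@H](C(=O)N3CCC(F)(F)CC3)C2)cc1` gives 560 nM in this assay

Compound 3 stands highest of the three numbers: it is a 4.3-fold higher number from compound 2 to compound 3 (0.64 log units; beyond the scatter) and an 11-fold higher number from compound 1 to compound 3 (1.05 log units; beyond the scatter). Compound 4 `CC(C)NS(=O)(=O)c1ccc(S(=O)(=O)N2CCC[C@@H](C(=O)N3CCC(F)(F)CC3)C2)cc1` differs from compound 3 by isopropylamino in place of dimethylamino on a sulfonyl sulfur. Among the measured compounds shown here, the steps that bear on this change are the two that lead into compound 3, an 11-fold higher number from compound 1 to compound 3 (1.05 log units; beyond the scatter) and a 4.3-fold higher number from compound 2 to compound 3 (0.64 log units; beyond the scatter), both of which replace a carbon-linked group with the dimethylamino group. Compound 4 keeps a nitrogen on the sulfonyl sulfur but carries the isopropyl group that compound 1 has; a modest step toward a lower number is therefore expected, short of compound 1. The estimate for compound 4 is 250 nM, between 80 nM and 800 nM, a step of a 2.2-fold lower number from compound 3 to compound 4 (0.35 log units; beyond the scatter).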

Compound 4, half-maximal inhibitory concentration: 470 nM
Compound 4: middle estimate off by 1.9-fold (0.27 log units), on the low side, and the stated range covers the measured number.
By their numbers in this assay, from the lowest: compound 1; then compound 2; then compounds 4 and 3 (each within the scatter of the next).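

In this assay, isopropylamino in place of dimethylamino on a sulfonyl sulfur gives a 1.2-fold lower number from compound 3 to compound 4 (0.08 log units; within the scatter), so swapping one nitrogen substituent pattern for the other, which adds a hydrogen-bond donor, makes no clear difference here. With the isopropyl group kept, putting a nitrogen on the sulfonyl sulfur gives a 9.4-fold higher number from compound 1 to compound 4 (0.97 log units; beyond the scatter). Compound 4 also stands apart from the cyclopropyl compound, with a 3.6-fold higher number from compound 2 to compound 4 (0.56 log units; beyond the scatter), so both nitrogen-linked compounds lie apart from both carbon-linked ones. Going by these compounds, whether a tert-butyl group on the sulfonyl sulfur would match compound 1, or an unsubstituted amino group would match compound 3, remains open. Nothing available here explains why the linking atom matters.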